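The source may report more compounds than this note shows. Statements on the series, on what has been measured and on what is new or still open speak of the compounds shown alone.

Measured in an ADME assay on GES1 cells (Homo sapiens) for inhibition, read by MTT assay, with a stated time of 72 h; on this read-out lower numbers stand for stronger inhibition and higher numbers for weaker inhibition:
- Compound 1 `C#CCSc1nc2nc(C)cc(Nc3cc(-c4ccccc4)[nH]n3)n2n1`: 45700 nM
- Compound 2 `Cc1ccc(CSc2nc3nc(C)cc(Nc4cc(-c5ccccc5)[nH]n4)n3n2)cc1`: 36200 nM

Compound 2 holds the lower of these two numbers, but the gap is small: a 1.3-fold lower number from compound 1 to compound 2 (0.10 log units; within the scatter). Compound 3 `Cc1cc(Nc2cc(-c3ccccc3)[nH]n2)n2nc(SCC3CC3)nc2n1` has not been measured. It carries cyclopropyl in place of 4-methylphenyl on a saturated chain carbon bound to a sulfur. Among the compounds with values here, the only measured step at this place is the one that gave compound 2, a 1.3-fold lower number from compound 1 to compound 2 (0.10 log units; within the scatter), so two quite different groups there gave numbers that cannot be told apart. Within the data shown here, only that single step bears on the change, so the expectation is loose, and no shift beyond the scatter is expected in this assay. The expected step is a 1.2-fold higher number from compound 2 to compound 3 (0.06 log units; within the scatter). The estimate for compound 3 is 42000 nM, with an expected range from 20000 nM to 90000 nM.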

Compound 3, half-maximal inhibitory concentration: > 50000 nM
Compound 3: a limit, no number (the forecaster's own chance of this, stated with the estimate: 10%); at least 1.1-fold (0.07 log units) between middle value and limit.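

In this assay, compound 3 reads only as a limit of the assay, not as a number: the limit of > 50000 nM in this assay, at which 1 of the 3 values shown sits. The steps therefore give only floors, an at least 1.3-fold higher number from compound 2 to compound 3 (0.14 log units; that floor lies within the scatter) and an at least 1.0-fold higher number from compound 1 to compound 3 (0.03 log units; that floor lies within the scatter), and neither floor shows a shift beyond the scatter. From the compounds shown here alone, with cyclopropyl, a third group on the saturated chain carbon bound to a sulfur reaches the assay's limit, so its true distance from 4-methylphenyl and ethynyl remains unknown.

Going by these compounds, whether any group at this place can move the number beyond the scatter stays open. The compounds shown include no amine or carboxylic acid there.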